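Chloro to Bromo: One Change Across Two Pairs

A few compounds are considered here, and "the series" means these few. Any claim that something is new, unique, unknown or untested is made for them only; others in the source may bear on it.

Compound 1 `CC1(C)CC(=O)C(C(=S)SCCO)=C(Nc2ccc(Cl)cc2)C1`: in a functional assay on cells (blood, Homo sapiens) for inhibition, read by chemiluminescence, with a stated time of 30 min (on this read-out higher numbers stand for weaker inhibition and lower numbers for stronger inhibition), compound 1 reaches only the limit > 100 ug/mL, not a number.
Compound 2 `CC(=O)OC[C@H]1O[C@@H](SC(=S)C2=C(Nc3ccc(Cl)cc3)CC(C)(C)CC2=O)[C@H](OC(C)=O)[C@@H](OC(C)=O)[C@@H]1OC(C)=O`: in this assay compound 2 gives 90 ug/mL.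
Compound 3 `CC1(C)CC(=O)C(C(=S)SCCO)=C(Nc2ccc(Br)cc2)C1`: in this assay compound 3 reaches only the limit > 100 ug/mL, not a number.

Compound 4 `CC(=O)OC[C@H]1O[C@@H](SC(=S)C2=C(Nc3ccc(Br)cc3)CC(C)(C)CC2=O)[C@H](OC(C)=O)[C@@H](OC(C)=O)[C@@H]1OC(C)=O` is not yet measured. It differs from compound 2 by bromo in place of chloro on an aromatic carbon. The same change separates compound 1 from compound 3, (bromo in place of chloro on an aromatic carbon), yet there it gives a step that the two limits leave unreadable from compound 1 to compound 3, since both values sit at the limit of > 100 ug/mL in this assay, at which 2 of the 3 values shown sit. How the core of compound 2 differs from that of compound 1 is not broken down here. Only compound 2 yields a number, and that number lies close to the limit. With no readable step to lean on, compound 4 is expected to move only by a 1.1-fold higher number from compound 2 to compound 4 (0.05 log units; within the scatter). Compound 4 is therefore estimated at 100 ug/mL, within a range from 50 ug/mL to 200 ug/mL, and a fair chance remains that only a limit is reported.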

Compound 4, half-maximal inhibitory concentration: > 100 ug/mL
Compound 4 gave a limit, no number; the forecaster's own chance of this, stated with the estimate: 50%; the middle value lies on the limit itself.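

Bromo in place of chloro gives an at least 1.1-fold higher number from compound 2 to compound 4 (0.04 log units; that floor lies within the scatter); this is only a floor, so it shows no clear effect of the change on this core. The same change between compound 1 and compound 3 cannot be read, so the data show neither that the effect carries from one core to the other nor that it fails to. Little more can be said because most values in this small set are limits, not numbers: the limit of > 100 ug/mL in this assay, at which 3 of the 4 values shown sit.

The compounds shown leave open whether an amine or a carboxylic acid in place of chloro or bromo would give a clear number in this assay. They also leave open whether a methoxy group there would behave differently on the two cores.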